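This account rests on a few compounds, and the source may have more. Where it says the series, first, only, none or still open, it means among the compounds named here.

Going by the values given here, compound 1 `CC(C)=CCc1cc(C(=O)Nc2cc3ccc(OCC4CCN(C)C4)c(C)c3oc2=O)ccc1O` holds the only plain number of the three measured: in a functional assay on MCF7 cells (Homo sapiens) for antiproliferative activity (on this read-out lower numbers stand for stronger inhibition and higher numbers for weaker inhibition), compound 1 gives 1550 nM. Compound 2 `CC(C)=CCc1cc(C(=O)Nc2cc3ccc(OCCCNc4ccccc4)c(C)c3oc2=O)ccc1O` reaches only a limit of this assay, namely > 50000 nM. Compound 3 `CC(C)=CCc1cc(C(=O)Nc2cc3ccc(OCCCN(C)c4ccccc4)c(C)c3oc2=O)ccc1O` likewise stops at the limit > 50000 nM. Both departures from compound 1 are large: an at least 32-fold higher number from compound 1 to compound 2 (1.50 log units; beyond the scatter) and an at least 32-fold higher number from compound 1 to compound 3 (1.50 log units; beyond the scatter), whereas a step that the two limits leave unreadable from compound 2 to compound 3; both rest on (the limit of > 50000 nM in this assay, at which 2 of the 3 values shown sit).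

Compound 4 `CC(C)=CCc1cc(C(=O)Nc2cc3ccc(OCCCN[C@H](C)c4ccccc4)c(C)c3oc2=O)ccc1O` carries the change (2-((1-phenylethyl)amino)ethyl in place of 1-methylpyrrolidin-3-yl on a saturated chain carbon bound to an oxygen on an aromatic ring). It replaces the 1-methylpyrrolidin-3-yl of compound 1 by an open chain bearing a phenyl, as compounds 2 and 3 do, so a large rise in number is expected, a 19-fold higher number from compound 1 to compound 4 (1.29 log units; beyond the scatter). Compound 4 is therefore estimated at 30000 nM, within 5000 nM to 80000 nM, with a fair chance that only a limit is reported.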

Compound 4, half-maximal inhibitory concentration: 1450 nM
Compound 4: middle estimate off by 21-fold (1.32 log units), on the high side, outside the stated range (below it).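

At this position, an open chain bearing a phenyl can stand in for the 1-methylpyrrolidin-3-yl, with a 1.1-fold lower number from compound 1 to compound 4 (0.03 log units; within the scatter). What separates the open-chain compounds is the group on the amine nitrogen: 1-phenylethyl in place of phenyl gives an at least 34-fold lower number from compound 2 to compound 4 (1.53 log units; beyond the scatter), and (1-phenylethyl)amino in place of methyl(phenyl)amino gives an at least 34-fold lower number from compound 3 to compound 4 (1.53 log units; beyond the scatter). Both of these steps start from a limit, not a number: the limit of > 50000 nM in this assay, at which 2 of the 4 values shown sit.

The compounds shown leave open how the opposite stereoisomer of the 1-phenylethyl group or a benzyl on the amine nitrogen would read. They also leave open the effect of a shorter or longer chain.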